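The source may hold more compounds than are shown below. What is called first, only, known or untested is meant among the compounds shown, and "the series" means these compounds.

Compound 1 `CCn1c(C(=O)NC2(CO)CC2)ccc1C(CC)(CC)c1ccc(OCS(=O)(=O)c2ccccc2)c(C)c1` (28800 nM)
Compound 2 `CCn1c(C(=O)NCCCO)ccc1C(CC)(CC)c1ccc(OCS(=O)(=O)c2ccccc2)c(C)c1` (42000 nM)
Compound 3 `CCn1c(C(=O)NC2(C(=O)O)CC2)ccc1C(CC)(CC)c1ccc(OCS(=O)(=O)c2ccccc2)c(C)c1` (not yet measured)

In a functional assay on MCF7 cells (Homo sapiens) for antiproliferative activity, read by MTT assay, with a stated time of 24 h (a higher number here means a weaker inhibitor, a lower number a stronger inhibitor), compound 2 gives (42000 nM) and cannot be separated from compound 1 (28800 nM). Compound 3 swaps one group on the amide-type nitrogen (1-carboxycyclopropyl in place of 3-hydroxypropyl on an amide-type nitrogen). Among the measured compounds shown here, no measured compound carries the 1-carboxycyclopropyl group, so the evidence is indirect. For the measured compounds named here, the only measured change at this nitrogen, in compound 2, was small (a 1.5-fold higher number from compound 1 to compound 2 (0.16 log units; within the scatter)). No shift beyond the scatter is therefore expected, and the estimate means only (a 1.2-fold lower number from compound 2 to compound 3 (0.08 log units; within the scatter)). Compound 3 is expected near (35000 nM), within an estimated range from (12000 nM) to (100000 nM).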

Compound 3, half-maximal inhibitory concentration: 41200 nM
Compound 3: the middle estimate sits 1.2-fold (0.07 log units) below what was measured, and the stated range covers the measured number.
By their numbers in this assay, from the lowest: compounds 1, 3 and 2 (each within the scatter of the next).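

In this assay, a carboxy group on this amide-type nitrogen substituent behaves like the alcohols: the step is a 1.0-fold lower number from compound 2 to compound 3 (0.01 log units; within the scatter) and, on the same cyclopropyl ring, with carboxy in place of hydroxymethyl, a 1.4-fold higher number from compound 1 to compound 3 (0.16 log units; within the scatter). The three compounds therefore cannot be told apart, whether the end group is a hydroxyl or a carboxy group. Nothing here gives a reason for this. On these data alone, whether an amine or a much longer chain on this nitrogen would move the number beyond the scatter stays open.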